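Moving the fluorine on the methoxyphenyl ring

The source may report more compounds than this note shows. Statements on the series, on what has been measured and on what is new or still open speak of the compounds shown alone.

Of the compounds shown here, three with a shared core have been measured in a functional assay on CHO cells for agonist activity at metabotropic glutamate receptor 2 (Homo sapiens), read by scintillation counting and GTPgammaS binding, with a stated time of 30 min; a lower number here means a smaller maximal response, a higher number a larger maximal response. Compound 1 `COc1ccc(F)cc1C1CCN(c2ccn3c(CC(F)(F)F)nnc3c2Cl)CC1` gives 340%, compound 2 `COc1ccccc1C1CCN(c2ccn3c(CC4CC4)nnc3c2Cl)CC1` gives 345%, and compound 3 `COc1ccc(F)cc1C1CCN(c2ccn3c(CC4CC4)nnc3c2Cl)CC1` gives 283%. Compound 3 thus stands lowest of the three on the largest response: the step of a number 57 percentage points lower from compound 1 to compound 3 (beyond the scatter) and the step of a number 62 percentage points lower from compound 2 to compound 3 (beyond the scatter) both lead down to it, each beyond the scatter.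

Compound 4 `COc1cccc(F)c1C1CCN(c2ccn3c(CC4CC4)nnc3c2Cl)CC1` keeps the same atoms as compound 3 but joins them differently: 2-fluoro-6-methoxyphenyl in place of 5-fluoro-2-methoxyphenyl on a saturated ring carbon. Within the data shown here, no measured step moves the fluorine from one aromatic carbon to another, so the change has no direct precedent. Among the measured compounds shown here, the one step that touches the fluorine at all, a number 62 percentage points lower from compound 2 to compound 3 (beyond the scatter), shows that placing fluoro where hydrogen stood lowered the largest response by a large amount, while compound 2 without fluoro sits higher. The new position may or may not carry the same cost, so the expectation is a modest step upward from compound 3 toward compound 2, with wide uncertainty.

Compound 4 is therefore expected to give 310% in this assay, in an estimated range from 240% to 380%, a step of a number 27 percentage points higher from compound 3 to compound 4 (beyond the scatter).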

Compound 4, largest response reached (Emax), in percent of the reference or control that the assay uses: 304%
The estimate for compound 4 lay 6 percentage points above the measured number; the measured number falls inside the stated range.
By their numbers in this assay, from the lowest: compound 3; then compound 4; then compounds 1 and 2 (each within the scatter of the next).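

In this assay, the same atoms joined differently on the aryl group give a distinct result: 2-fluoro-6-methoxyphenyl in place of 5-fluoro-2-methoxyphenyl on a saturated ring carbon means a number 21 percentage points higher from compound 3 to compound 4 (beyond the scatter) and so separates the two fluorinated isomers beyond the scatter. Fluoro in place of hydrogen on an aromatic carbon also goes with a lower largest response in the new arrangement, with a number 41 percentage points lower from compound 2 to compound 4 (beyond the scatter) standing alongside a number 62 percentage points lower from compound 2 to compound 3 (beyond the scatter) as the earlier step, so compound 2 without fluoro stays above both fluorinated compounds. No measurement is available to explain why the two arrangements differ.

The compounds shown leave open whether the change at the other end of the molecule, seen as a number 57 percentage points lower from compound 1 to compound 3 (beyond the scatter) with 5-fluoro-2-methoxyphenyl, would carry over to 2-fluoro-6-methoxyphenyl. They also leave open whether the drop belongs to fluoro itself, since a chloro, a methyl or a nitrile on the same aromatic carbons would be needed to show whether other groups follow the same order.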